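The compounds below may be only part of what the source reports. "The series", "measured", "known", "first", "only" and "open" are said of these compounds alone.

In a functional assay on MDA-MB-435 cells (Homo sapiens) for antiproliferative activity, read by CellTiter-Glo, with a stated time of 96 h (a lower number here means a stronger inhibitor, a higher number a weaker inhibitor), compound 3 (`COc1ccc(-c2nsc3c2NC(=O)CC3c2cccc(F)c2)cc1`) gives 1410 nM and lies within the scatter of compound 2 (`COc1ccc(-c2nsc3c2NC(=O)CC3c2cccc(Cl)c2)cc1`) at 792 nM while compound 1 (`COc1ccc(-c2nsc3c2NC(=O)CC3c2ccc3c(c2)OCCO3)cc1`) at 349 nM stands at a clearly lower number. Compound 4 (`COc1ccc(-c2nsc3c2NC(=O)CC3c2ccsc2)cc1`) carries thiophen-3-yl in place of 3-fluorophenyl on a saturated ring carbon. Among the measured compounds shown here, the only measured step between single-place neighbours is fluoro in place of chloro on an aromatic carbon (a 1.8-fold higher number from compound 2 to compound 3 (0.25 log units; within the scatter)) and it stays within the scatter. For the measured compounds named here, that step does not test a change of ring, and no measured compound has a five-membered aromatic ring on this carbon. The values of compound 1 and compound 3 do show that the group on this carbon can move the number beyond the scatter, so the expectation is loose. The estimated change is (a 1.3-fold lower number from compound 3 to compound 4 (0.11 log units; within the scatter)) and no step beyond the scatter is expected in this assay. In this assay the estimate for compound 4 is 1100 nM (expected range 450 nM to 2600 nM).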

Compound 4, half-maximal inhibitory concentration: 80.7 nM
Beside the measured number, compound 4's estimate is 14-fold (1.13 log units) above it; the whole stated range lies above it.
By their numbers in this assay, from the lowest: compound 4; then compound 1; then compounds 2 and 3 (each within the scatter of the next).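

In this assay the group on the saturated ring carbon can move the number much further than the exchange of halogen indicated: thiophen-3-yl in place of 3-fluorophenyl gives a 17-fold lower number from compound 3 to compound 4 (1.24 log units; beyond the scatter), and thiophen-3-yl in place of 3-chlorophenyl gives a 9.8-fold lower number from compound 2 to compound 4 (0.99 log units; beyond the scatter). This position therefore accepts a five-membered aromatic ring with 1 hetero atom, and on the compounds shown the change of ring type matters more than the choice between fluoro and chloro. Nothing available accounts for the size of these steps.

The compounds shown do not settle whether the result belongs to thiophen-3-yl in particular or extends to other five-membered aromatic rings, such as thiophen-2-yl, furan-3-yl or pyrazole. From the compounds shown here alone, how a substituent on the thiophene, such as a methyl group, an amine or a carboxylic acid, would affect the number also remains open.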